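Smaller amide substituent on the trifluoromethyl carbinol naphthalene core

The source may hold more compounds than are shown below. What is called first, only, known or untested is meant among the compounds shown, and "the series" means these compounds.

Compound 1 `CC(C)C(=O)Nc1c(C(O)(C(F)(F)F)C(F)(F)F)ccc2ccccc12`: 6630 nM
Compound 2 `O=C(Nc1c(C(O)(C(F)(F)F)C(F)(F)F)ccc2ccccc12)C1CCCC1`: 495 nM

In an assay on LtK cells with ATP-sensitive inward rectifier potassium channel 11 (Homo sapiens) as the target (a lower number here means that less compound is needed, a higher number that more compound is needed for the effect), compound 2 holds the lowest number of the two, with compound 1 a 13-fold lower number from compound 1 to compound 2 (1.13 log units; beyond the scatter) step away. Compound 3 `COCC(=O)Nc1c(C(O)(C(F)(F)F)C(F)(F)F)ccc2ccccc12` carries methoxymethyl in place of cyclopentyl on a carbonyl carbon. Among the measured compounds shown here, the one measured step that bears on this, a 13-fold lower number from compound 1 to compound 2 (1.13 log units; beyond the scatter), shows that leaving cyclopentyl for a smaller group on this carbonyl carbon raised the number strongly; methoxymethyl is a move in the same direction. A large rise is therefore expected, giving a step of about a 16-fold higher number from compound 2 to compound 3 (1.21 log units; beyond the scatter). For compound 3 the estimate is 8000 nM, within 2000 nM to 30000 nM.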

Compound 3, half-maximal effective concentration: 213 nM
For compound 3 the middle estimate is 38-fold (1.57 log units) above the measured one; measured number outside the range, below it.
By their numbers in this assay, from the lowest: compound 3; then compound 2; then compound 1.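

In this assay, the size of the group on this carbonyl carbon does not set the number by itself: replacing cyclopentyl with the smaller methoxymethyl gives a 2.3-fold lower number from compound 2 to compound 3 (0.37 log units; beyond the scatter), so the drop in size from compound 2 to compound 1 does not predict this result. Placing methoxymethyl where isopropyl stood gives a 31-fold lower number from compound 1 to compound 3 (1.49 log units; beyond the scatter), a far larger change between two open-chain groups. Nothing measured here gives a reason for this order.

The compounds shown leave open whether the oxygen of methoxymethyl matters, which a propyl chain, with carbon in place of that oxygen, could test. From the compounds shown here alone, how a longer chain such as 2-methoxyethyl would read also stays open.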